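Alkene aryl variation in a tetrahydropyran series

The source may hold more compounds than are shown below. What is called first, only, known or untested is meant among the compounds shown, and "the series" means these compounds.

Measured compounds:
compound 1 `COc1ccccc1/C=C/C[C@H]1C[C@@H]([C@@H](O)c2ccccc2)CO[C@@H]1c1ccccc1`: 14700 nM
compound 2 `COc1ccc(/C=C/C[C@H]2C[C@@H]([C@@H](O)c3ccccc3)CO[C@@H]2c2ccc(OC)c(OC)c2)cc1OC`: 15500 nM
compound 3 `COc1ccc(/C=C/C[C@H]2C[C@@H]([C@@H](O)c3ccc(OC)c(OC)c3)CO[C@@H]2c2ccc(OC)c(OC)c2)cc1OC`: 23800 nM

In a functional assay on HeLa cells (Homo sapiens) for cytotoxicity, read by WST assay, with a stated time of 48 h (a lower number here means a stronger inhibitor, a higher number a weaker inhibitor), compound 1 gives 14700 nM, the lowest of the three numbers, yet compound 2 and compound 3 both lie within the scatter of it. For the measured compounds named here, the only single-site step measured is a 1.5-fold higher number from compound 2 to compound 3 (0.19 log units; within the scatter), a change on a saturated chain carbon bound to an oxygen on a saturated carbon and a saturated ring carbon, so it does not touch the position varied here. Compound 4 `O=[N+]([O-])c1cccc(/C=C/C[C@H]2C[C@@H]([C@@H](O)c3ccccc3)CO[C@@H]2c2ccccc2)c1` differs from compound 1 by 3-nitrophenyl in place of 2-methoxyphenyl on a double-bonded chain carbon bound to a double-bonded chain carbon. Going by the values given here, no measured pair varies the aryl on the double-bonded chain carbon, and the series so far shows no step beyond the scatter, so none is expected here either. Compound 4 is estimated at 15000 nM, range 5000 nM to 45000 nM. The expected step is a 1.0-fold higher number from compound 1 to compound 4 (0.01 log units; within the scatter).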

Compound 4, half-maximal inhibitory concentration: 7850 nM
Beside the measured number, compound 4's estimate is 1.9-fold (0.28 log units) above it, and the stated range covers the measured number.
By their numbers in this assay, from the lowest: compounds 4, 1, 2 and 3 (each within the scatter of the next, the first and the last beyond it).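

In this assay, 3-nitrophenyl in place of 2-methoxyphenyl on a double-bonded chain carbon bound to a double-bonded chain carbon gives a 1.9-fold lower number from compound 1 to compound 4 (0.27 log units; within the scatter) as the first step read at this position. The aryl group here can therefore be exchanged, with a different substituent in a different place on the ring, without a step beyond the scatter. Nothing at hand bears on the reason for this step.

Going by these compounds, the two aryl groups differ in both substituent and placement, so the contribution of each stays open. Also open, on these data alone, is what an aryl group carrying an amine or a carboxylic acid would give on the same carbon.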